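From 4-fluorophenyl to 2-chlorophenyl

This account rests on a few compounds, and the source may have more. Where it says the series, first, only, none or still open, it means among the compounds named here.

- Compound 1 `CCN(CC)C(=S)SC(CC(=O)c1ccccc1)c1ccc(C)cc1`: 20000 nM
- Compound 2 `CCN(CC)C(=S)SC(CC(=O)c1ccccc1)c1ccc(F)cc1`: 700 nM

Both values come from a functional assay on MCF7 cells (Homo sapiens) for cytotoxicity, read by MTT assay, with a stated time of 48 h; on this read-out higher numbers stand for weaker inhibition and lower numbers for stronger inhibition. Compound 2 holds the lower of the two numbers, so it is the stronger inhibitor of this pair. Compound 3 `CCN(CC)C(=S)SC(CC(=O)c1ccccc1)c1ccccc1Cl` awaits measurement. It differs from compound 2 as follows: 2-chlorophenyl in place of 4-fluorophenyl on a saturated chain carbon bound to a saturated chain carbon and a sulfur. In words, 2-chlorophenyl stands in place of 4-fluorophenyl on a saturated chain carbon bound to a saturated chain carbon and a sulfur. For the measured compounds named here, only one measured step bears on this change: a 29-fold lower number from compound 1 to compound 2 (1.46 log units; beyond the scatter). Going by the values given here, that large step, fluoro in place of methyl on an aromatic carbon, suggests that changes on this ring can matter, but no chlorine-bearing compound has been measured. Among the compounds with values here, a moderate rise in this assay is therefore expected, since compound 2 sits at the low end of only two values. The estimated change is a 4.3-fold higher number from compound 2 to compound 3 (0.63 log units; beyond the scatter). For compound 3 the expected value is 3000 nM, with an estimated range of 600 nM to 15000 nM.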

Compound 3, half-maximal inhibitory concentration: 4500 nM
Beside the measured number, compound 3's estimate is 1.5-fold (0.18 log units) below it; measured number inside the range.
By their numbers in this assay, from the lowest: compound 2; then compound 3; then compound 1.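

In this assay putting 2-chlorophenyl in place of 4-fluorophenyl on the saturated chain carbon bound to a saturated chain carbon and a sulfur gives a 6.4-fold higher number from compound 2 to compound 3 (0.81 log units; beyond the scatter) and so weakens inhibition, while a 4.4-fold lower number from compound 1 to compound 3 (0.65 log units; beyond the scatter) shows that the 2-chlorophenyl compound still inhibits more strongly than the 4-methylphenyl compound. This places compound 3 between the other two and shows that a second halogen-bearing ring also outperforms the 4-methylphenyl ring, though not as strongly as 4-fluorophenyl does. No measurement available here explains these differences.

Compounds 2 and 3 differ in both the halogen and its ring position, so the effects of these two changes cannot be separated. A 4-chlorophenyl or 2-fluorophenyl ring would help separate them, while an amine on the ring would test a different kind of group.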